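Fluoro in place of hydrogen on the aryl ring of compound 2

This account rests on a few compounds, and the source may have more. Where it says the series, first, only, none or still open, it means among the compounds named here.

Compound 2 `CCC(C(=O)N1CCN(c2ccccc2)CC1)N1C(=O)CCC1=O` is the unsubstituted parent of this small set. In a functional assay on the whole organism (strain Swiss) with Mus musculus as the target, in the maximal electroshock model, with a stated time of 0.25 h, at a dose of 300 mg/kg by the intraperitoneal route (a lower number here means a weaker effect, a higher number a stronger effect of the compound at the dose given), compound 2 gives 75%. Compound 1 `CCC(C(=O)N1CCN(c2cccc(Cl)c2)CC1)N1C(=O)CCC1=O` gives 75% in this assay, so the two are level at the digits shown and together hold the highest of the three numbers; the move no change at the digits printed from compound 1 to compound 2 (within the scatter) stays within the scatter, with hydrogen in place of chloro on an aromatic carbon. Compound 3 `CCC(C(=O)N1CCN(c2ccccc2C(F)(F)F)CC1)N1C(=O)CCC1=O` gives 25%, and the step of a number 50 percentage points lower from compound 2 to compound 3 (beyond the scatter) is large, with trifluoromethyl in place of hydrogen on an aromatic carbon.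

Compound 4 `CCC(C(=O)N1CCN(c2cccc(F)c2)CC1)N1C(=O)CCC1=O` is not yet measured. Its difference from compound 2 is fluoro in place of hydrogen on an aromatic carbon. For the measured compounds named here, the step that bears most on it is the one between compound 1 and compound 2, where chloro against hydrogen on an aromatic carbon made no difference beyond the scatter; compound 4 carries fluoro, another halogen, in place of hydrogen. The step from compound 2 to compound 3 shows that a ring substituent can cost much, but that substituent was trifluoromethyl. On balance no step beyond the scatter is expected, no change at the digits printed from compound 2 to compound 4 (within the scatter). The value of compound 4 in this assay is therefore estimated at 75%, with a range from 50% to 100% kept wide because of the large drop seen in a number 50 percentage points lower from compound 2 to compound 3 (beyond the scatter).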

Compound 4, a percentage reported as activity, at one dose (the size of the read-out at that dose, not a potency): 75%
Beside the measured number, compound 4's estimate shows no gap at the digits printed; measured number inside the range.
By their numbers in this assay, from the lowest: compound 3; then compounds 1, 2 and 4 (each within the scatter of the next).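

In this assay, the place on an aromatic carbon meta to a large group now holds hydrogen, chloro and fluoro with no separation in the read-out: phenyl to 3-fluorophenyl gives no change at the digits printed from compound 2 to compound 4 (within the scatter), and fluoro in place of chloro gives no change at the digits printed from compound 1 to compound 4 (within the scatter). The earlier compounds shown here showed only chloro at this place, so a second halogen now fits the same picture, and the large step of a number 50 percentage points lower from compound 2 to compound 3 (beyond the scatter) does not extend to every ring substituent in this small set. No measurement is available that would explain this flat result.

The drop at compound 3 remains tied to a single group at a single place, so the compounds shown do not tell whether it follows trifluoromethyl itself or where that group sits, and trifluoromethyl at the place meta to a large group would separate the two. Also open, going by these compounds, are whether a methoxy, an amine or a carboxylic acid at this place would stay level with compounds 1, 2 and 4, and whether these three would separate at any dose other than the single one read here.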